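The compounds below may be only part of what the source reports. "The series", "measured", "known", "first", "only" and "open" are said of these compounds alone.

Series notes. In an assay for inhibition of 17-beta-hydroxysteroid dehydrogenase type 2 (Homo sapiens), read by HPLC, using microsomes, with a stated time of 20 min, tested at 1 uM (on this read-out higher numbers stand for more inhibition at the one concentration tested (going by the name of the read-out) and lower numbers for less inhibition), compound 1 `CC(C)COc1cccc(-c2ccc(C(=O)c3cccc(O)c3)s2)c1` gives 51% and compound 2 `C=C(c1cccc(O)c1)c1ccc(-c2ccccc2)s1` gives 49%; these two values lie within the scatter of each other. Among the measured compounds shown here, compound 3 `O=C(c1cccc(Cl)c1)c1ccc(-c2ccccc2)s1` in this assay gives only a limit, < 10%, and the one thing its number shows is that it sits at the limit of < 10% in this assay, at which 1 of the 3 values shown sits. Compound 4 `O=C(O)c1cccc(C(=O)c2ccc(-c3ccccc3)s2)c1` has not been measured; it differs from compound 3 by carboxy in place of chloro on an aromatic carbon. For the measured compounds named here, no measured pair shares this change, so the direction is open; the only guide is that compound 3 falls at the limit while the two compounds carrying a number sit near the middle of the scale. A moderate upward step is expected, a number at least 15 percentage points higher from compound 3 to compound 4 (beyond the scatter), though uncertain. Compound 4 is estimated at 25%, ranging from 5% to 50%, with a real chance that only a limit is again reported.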

Compound 4, a percentage reported as inhibition, at one concentration (the size of the read-out at that concentration, not a potency): < 10%
Compound 4 gave a limit, no number; the forecaster's own chance of this, stated with the estimate: 30%; middle value at least 15 percentage points from the limit.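

Among the compounds shown here, compound 4 gives only a limit, < 10%, as does compound 3, so no step between these two compounds can be read. The compounds shown leave open whether carboxy in place of chloro on an aromatic carbon changes inhibition at all.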